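A fluorophenyl change on a saturated ring carbon

The source may hold more compounds than are shown below. What is called first, only, known or untested is meant among the compounds shown, and "the series" means these compounds.

- compound 1 `NS(=O)(=O)c1ccc(N2N=C(c3ccccc3)CC2c2ccccc2Cl)cc1`: 26000 nM
- compound 2 `NS(=O)(=O)c1ccc(N2N=C(c3ccc(Oc4ccccc4)cc3)CC2c2cccc(F)c2)cc1`: 28000 nM

In an ADME assay on Vero 76 cells (Chlorocebus sabaeus) for cytotoxicity, read by MTT assay, with a stated time of 96 h (a higher number here means that more compound is tolerated, a lower number that less compound is tolerated), compound 1 gives 26000 nM and compound 2 gives 28000 nM. These two numbers lie within the usual scatter of each other, so compound 2 cannot be told apart from compound 1 on the data so far.

Compound 3 `NS(=O)(=O)c1ccc(N2N=C(c3ccc(Oc4ccccc4)cc3)CC2c2ccc(F)cc2)cc1` has not yet been measured. It differs from compound 2 in one place: 4-fluorophenyl in place of 3-fluorophenyl on a saturated ring carbon. In words, 4-fluorophenyl stands in place of 3-fluorophenyl on a saturated ring carbon, and the rest of the structure is unchanged.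

Among the measured compounds shown here, no two measured compounds differ in just one place, so the data offer no direct precedent for this change. The expectation therefore rests on compound 2 at 28000 nM, and no step beyond the scatter is expected in either direction in this assay. The expected outcome is no change at the digits printed from compound 2 to compound 3 (within the scatter). For compound 3 the estimated value is 28000 nM, with an expected range of 15000 nM to 55000 nM.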

Compound 3, half-maximal cytotoxic concentration: 25000 nM
The estimate for compound 3 lay 1.1-fold (0.05 log units) above the measured number; low and high end bracket the measured number.
By their numbers in this assay, from the lowest: compounds 3, 1 and 2 (each within the scatter of the next).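

Among the compounds shown here, this is the first direct comparison at this position: in this assay, 4-fluorophenyl in place of 3-fluorophenyl on a saturated ring carbon gives a 1.1-fold lower number from compound 2 to compound 3 (0.05 log units; within the scatter). The two fluorophenyl groups, which have the same atoms joined differently, therefore cannot be told apart in this assay when the rest of the structure is unchanged, something the comparison of compound 1 and compound 2 could not show because those two differ in more than one place. Nothing measured here offers an explanation for this result.

The compounds shown leave open whether a step beyond the scatter would appear if the fluorine on this phenyl group gave way to a different substituent, such as an amine, a carboxylic acid or a longer chain. They also leave open whether the same lack of separation between 3-fluorophenyl and 4-fluorophenyl would hold if the rest of the structure were different, for example on a compound lacking the phenoxy group that compound 2 and compound 3 share.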